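Benzyl Replaces Pentafluorophenyl on a Silent Sulfonyl

The source may hold more compounds than are shown below. What is called first, only, known or untested is meant among the compounds shown, and "the series" means these compounds.

Three compounds share one core and differ only in the group on the aromatic nitrogen. Compound 1 `COc1ccc(-c2cc(=O)c3c(OC)cc(OC)cc3[nH]2)cc1` carries hydrogen there, and in a functional assay on KOPN-8 cells (Homo sapiens) for antiproliferative activity, with a stated time of 72 h (a higher number here means that more compound is needed for the effect, a lower number that less compound is needed), compound 1 gives only a limit, > 31100 nM. Compound 2 `COc1ccc(-c2cc(=O)c3c(OC)cc(OC)cc3n2S(=O)(=O)c2ccc(F)cc2)cc1` bears a (4-fluorophenyl)sulfonyl, and in this assay compound 2 likewise reaches only a limit, > 65500 nM. Compound 3 `COc1ccc(-c2cc(=O)c3c(OC)cc(OC)cc3n2S(=O)(=O)c2c(F)c(F)c(F)c(F)c2F)cc1` has a 2,3,4,5,6-pentafluorophenyl on the sulfonyl sulfur, and in this assay compound 3 again gives only a limit, > 34400 nM. Compound 3 thus stands nowhere definite: the steps a step that the two limits leave unreadable from compound 1 to compound 2 and a step that the two limits leave unreadable from compound 2 to compound 3 cannot be sized. Compound 4 `COc1ccc(-c2cc(=O)c3c(OC)cc(OC)cc3n2S(=O)(=O)Cc2ccccc2)cc1` differs by benzyl in place of 2,3,4,5,6-pentafluorophenyl on a sulfonyl sulfur. No readable step bears on this change, so no direction is expected. Compound 4 is estimated at 40000 nM (range 12000 nM to 120000 nM). The step that the limit leaves unreadable from compound 3 to compound 4 is expected to stay within scatter.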

Compound 4, half-maximal effective concentration: > 34400 nM
Compound 4: no number, only a limit; the forecaster's own chance of this, stated with the estimate: 80%; the middle value does not contradict the limit.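

For the compounds shown here, compound 4 gives only a limit in this assay, so no step linking it to compound 1, compound 2 or compound 3 can be read. Going by these compounds, with all four compounds at limits, what remains open is whether any group on the aromatic nitrogen changes antiproliferative activity.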